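Nitro in place of hydrogen on compound 1

The source may report more compounds than this note shows. Statements on the series, on what has been measured and on what is new or still open speak of the compounds shown alone.

In a functional assay on cells (Erythrocyte, Rattus norvegicus) for inhibition, read by hemolysis, with a stated time of 1 h (on this read-out higher numbers stand for weaker inhibition and lower numbers for stronger inhibition), compound 1 `COc1cc(OC)c(OC)cc1/C=C/C(=O)c1ccccc1` reads (2.23 ug/mL) and compound 2 `COc1cc(OC)c(OC)cc1/C=C/C(=O)c1ccc(O)cc1O` reads (2.37 ug/mL), so the two stand level within the scatter. Compound 3 `COc1cc(OC)c(OC)cc1/C=C/C(=O)c1ccc([N+](=O)[O-])cc1` is unmeasured and differs from compound 1 by nitro in place of hydrogen on an aromatic carbon as nitro in place of hydrogen on an aromatic carbon, para to a large group. Among the compounds with values here, the only measured step (a 1.1-fold higher number from compound 1 to compound 2 (0.03 log units; within the scatter)) lies within the scatter and involves different groups, so it offers thin guidance. Going by these compounds, no step beyond the scatter is expected, and the direction stays open. The expected step is small (a 1.1-fold higher number from compound 1 to compound 3 (0.03 log units; within the scatter)). Compound 3 is estimated at 2.4 ug/mL (range 1.1 ug/mL to 5.5 ug/mL).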

Compound 3, half-maximal inhibitory concentration: 2.34 ug/mL
For compound 3 the middle estimate is 1.0-fold (0.01 log units) above the measured one; low and high end bracket the measured number.
By their numbers in this assay, from the lowest: compounds 1, 3 and 2 (each within the scatter of the next).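

Nitro in place of hydrogen on an aromatic carbon, para to a large group, gives a 1.0-fold higher number from compound 1 to compound 3 (0.02 log units; within the scatter) in this assay. This position therefore takes a group of heavy atoms with no hydrogen-bond donors and the read-out stays level with the unsubstituted phenyl, as it did with the two hydroxyl groups of the 2,4-dihydroxyphenyl compound in a 1.1-fold higher number from compound 1 to compound 2 (0.03 log units; within the scatter). No data here bear on why the read-out stays level. Going by these compounds, whether an amine or a carboxylic acid at this same place would also stay level remains open.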